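This account rests on a few compounds, and the source may have more. Where it says the series, first, only, none or still open, it means among the compounds named here.

Three anilides built on one amide core have been followed in an ADME assay for pharmacokinetics, read by LC-MS, in phosphate buffer, with a stated time of 120 min, at pH 7.4, tested at 1 uM, in the presence of a further agent that is not named here; a lower number here means that the compound disappears faster, a higher number that the compound lasts longer. Compound 1 `O=C(/C=C/CN1CCCCC1)Nc1ccccc1` gives 2.95 h. Compound 2 `C=C(Cc1ccccc1)C(=O)Nc1ccccc1` reaches only a limit of the assay, > 8.53 h, so where it stands is known as a boundary rather than a number, as the limit of > 8.53 h in this assay, at which 1 of the 3 values shown sits, states. Compound 3 `O=C(/C=C/C(F)(F)F)Nc1ccccc1` gives 0.267 h, the shortest half-life among the three measured values.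

Compound 4 `C=C(COC)C(=O)Nc1ccccc1` has not yet been measured. It differs from compound 2 by methoxy in place of phenyl on a saturated chain carbon bound to a double-bonded chain carbon. Among the measured compounds shown here, no step between measured compounds matches this change, so the direction rests on expectation alone. A moderate shortening of the half-life from compound 2 is expected, an at least 1.8-fold lower number from compound 2 to compound 4 (0.27 log units; that floor lies within the scatter), though the range is wide. Compound 4 is estimated at 4.5 h, between 1.5 h and 12 h.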

Compound 4, half-life: 4.02 h
Compound 4: the middle estimate sits 1.1-fold (0.05 log units) above what was measured; low and high end bracket the measured number.
By their numbers in this assay, from the lowest: compound 3; then compounds 1 and 4 (each within the scatter of the next). At a limit, above all of these: compound 2.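

In this assay, among the compounds shown here, putting methoxy in place of phenyl on a saturated chain carbon bound to a double-bonded chain carbon gives an at least 2.1-fold lower number from compound 2 to compound 4 (0.32 log units; beyond the scatter) and is the first single change here that can be read. What sits at this place therefore moves the half-life beyond the usual scatter. The starting point of this step is a limit for compound 2: the limit of > 8.53 h in this assay, at which 1 of the 4 values shown sits.

On these data alone, how far the step really reaches stays open, as does whether losing the phenyl or gaining the methoxy carries it. A longer chain or a carboxylic acid at this place could help separate the two.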